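From an Aminophenyl to a Hydroxy-Methoxyphenyl Amide

The source may hold more compounds than are shown below. What is called first, only, known or untested is meant among the compounds shown, and "the series" means these compounds.

Compound 1, `CC(/C=N/Nc1ccc([N+](=O)[O-])cc1)=N\NC(=O)c1ccccc1O`, gives 1640 nM in a functional assay on cells (Splenocyte, Mus musculus, strain BALB/c) for inhibition, read by scintillation counting and thymidine incorporation, with a stated time of 72 h; a higher number here means a weaker inhibitor, a lower number a stronger inhibitor.
Compound 2, `CC(/C=N/Nc1ccc([N+](=O)[O-])cc1)=N\NC(=O)c1ccccc1F`, reaches only a limit of this assay, > 12000 nM.
Compound 3, `CC(/C=N/Nc1ccc([N+](=O)[O-])cc1)=N\NC(=O)c1ccccc1N`, gives 4900 nM.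

Among the numbers shown, compound 3 has the highest, meaning the weakest inhibition; compound 1 sits nearest, with a 3.0-fold higher number from compound 1 to compound 3 (0.48 log units; beyond the scatter). Compound 2 reports only a limit, and from that limit an at least 2.4-fold lower number from compound 2 to compound 3 (0.38 log units; beyond the scatter). Compound 4, `COc1cc(C(=O)N/N=C(C)/C=N/Nc2ccc([N+](=O)[O-])cc2)ccc1O`, changes the ring on the carbonyl: 4-hydroxy-3-methoxyphenyl in place of 2-aminophenyl on a carbonyl carbon. The measured steps each swap a single group on that ring, and hydroxy gave a lower number than amino; compound 4 carries a hydroxy again, now accompanied by a methoxy within a differently substituted ring. A modest expected step of a 2.0-fold lower number from compound 3 to compound 4 (0.29 log units; within the scatter) toward a lower number follows. Compound 4 is therefore estimated at 2500 nM, between 800 nM and 8000 nM.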

Compound 4, half-maximal inhibitory concentration: 5100 nM
Compound 4: middle estimate off by 2.0-fold (0.31 log units), on the low side; measured number inside the range.
By their numbers in this assay, from the lowest: compound 1; then compounds 3 and 4 (each within the scatter of the next). At a limit, above all of these: compound 2.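

Putting 4-hydroxy-3-methoxyphenyl in place of 2-aminophenyl on a carbonyl carbon gives a 1.0-fold higher number from compound 3 to compound 4 (0.02 log units; within the scatter), so these two quite different rings cannot be told apart here. Carrying a hydroxy is not enough to match the 2-hydroxyphenyl ring, since that swap gives a 3.1-fold higher number from compound 1 to compound 4 (0.49 log units; beyond the scatter). The step from the 2-fluorophenyl ring, an at least 2.3-fold lower number from compound 2 to compound 4 (0.37 log units; beyond the scatter), is read from a limit, not a number: the limit of > 12000 nM in this assay, at which 1 of the 4 values shown sits.

Still open, on these data alone, is whether the hydroxy or the methoxy of compound 4 matters more. As far as these compounds go, how a carboxylic acid or an ethoxy on this ring would read is also open.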